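Swapping the Furan Ring on a Thiazole Acetic Acid Core

This account rests on a few compounds, and the source may have more. Where it says the series, first, only, none or still open, it means among the compounds named here.

Measured so far:
- compound 1 `O=C(O)Cc1sc(C(c2ccc(F)cc2)c2ccc(F)cc2)nc1-c1ccco1` — 18 nM
- compound 2 `O=C(O)Cc1sc(C(c2ccccc2)c2ccccc2)nc1-c1ccc(F)c(F)c1` — 4.1 nM
- compound 3 `COc1ccc(C(c2ccccn2)c2nc(-c3ccc(Cl)cc3)c(CC(=O)O)s2)cc1` — 61 nM

These three compounds share a core carrying a carboxymethyl group and a diarylmethyl group, and differ in the aromatic ring attached to the core and in the substituents on the two aryl rings. In an in vitro assay on HEK385-7 cells for displacement of a labelled ligand from prostaglandin D2 receptor 2 (Homo sapiens) (a lower number here means a stronger inhibitor, a higher number a weaker inhibitor), compound 1 gives 18 nM. Of the three numbers it sits second highest: compound 2 gives 4.1 nM, a lower number beyond the usual scatter, while compound 3 gives 61 nM, a higher number, also beyond the scatter. Compound 3 differs from compound 1 in several places at once, so no single change can be read from that pair.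

Compound 4 `O=C(O)Cc1sc(C(c2ccc(F)cc2)c2ccc(F)cc2)nc1-c1ccnc(O)c1` has not yet been measured. Within the data shown here, it keeps the two fluorophenyl groups of compound 1 and changes only one ring: 2-hydroxypyridin-4-yl in place of furan-2-yl on an aromatic carbon. The new group sits on an aromatic carbon of a five-membered aromatic ring with 1 nitrogen and 1 sulfur, next to the ring nitrogen. From the compounds shown here alone, compound 2 shows that a six-membered aromatic ring at this place is compatible with a strong number, but that compound carries no hydroxyl group there and also has different aryl substituents, so the effect of the hydroxypyridine itself is unknown. A modest step in this assay, likely within the scatter and if anything toward a weaker number, is expected. For compound 4 the estimate is 30 nM, with a range from 8 nM to 120 nM, which means an expected step of a 1.7-fold higher number from compound 1 to compound 4 (0.22 log units; within the scatter).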

Compound 4, half-maximal inhibitory concentration: 68 nM
Compound 4: the middle estimate sits 2.3-fold (0.36 log units) below what was measured; measured number inside the range.
By their numbers in this assay, from the lowest: compound 2; then compound 1; then compounds 3 and 4 (each within the scatter of the next).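

Among these compounds, the first single-place change in this set, 2-hydroxypyridin-4-yl in place of furan-2-yl on an aromatic carbon, gives a 3.8-fold higher number from compound 1 to compound 4 (0.58 log units; beyond the scatter) in this assay. With the two fluorophenyl groups held fixed, this step points toward a weaker inhibitor and lies beyond the scatter, so the group at this position does affect the number. The step is modest, however, and the position still accepts a six-membered aromatic ring carrying a hydroxyl group without losing displacement of the labelled ligand. Nothing measured here says why the number rises.

The compounds shown leave open which part of the swap carries the step, since ring size, the ring nitrogen and the hydroxyl group all change together. A plain phenyl or a pyridin-4-yl without the hydroxyl, placed on the core of compound 1 with its two fluorophenyl groups, would help pull these apart, and a methoxy group in place of the hydroxyl would show whether the hydrogen-bond donor matters.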